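The source may hold more compounds than are shown below. What is called first, only, known or untested is meant among the compounds shown, and "the series" means these compounds.

Measured in an ADME assay on cells (Homo sapiens) for cytotoxicity, read by resazurin assay, with a stated time of 5 days; on this read-out higher numbers stand for lower toxicity in this test and lower numbers for higher toxicity in this test:
compound 1 `CCC1=C(C(=O)OCC2CCCCC2)C(c2cccc(O)c2)NC(=O)N1`: > 10000 nM
compound 2 `O=S(=O)(Cc1nc(-c2ccncc2)c2sccc2n1)c1cccc(Cl)c1`: > 50000 nM
compound 3 `COc1ccc(-c2nc(CC(O)c3cccc(Cl)c3)nc3ccsc23)cn1`: 31000 nM

The value for compound 1 is a limit of the assay, not a number. For compound 2 the value is also a limit, namely (the limit of > 50000 nM in this assay, at which 1 of the 3 values shown sits). Compound 3 alone gives a number. Compound 2 thus stands at a limit, with no measured number of its own to set against compound 3.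

Compound 4 `COc1ccc(Oc2nc(CS(=O)(=O)c3cccc(Cl)c3)nc3ccsc23)cc1` is not yet measured. It differs from compound 2 in one place: 4-methoxyphenoxy in place of pyridin-4-yl on an aromatic carbon. Going by the values given here, no step between measured compounds is available, so in this assay no direction can be drawn from the data; no step beyond the scatter is expected. Compound 4 is estimated at 40000 nM, with a range of 15000 nM to 100000 nM. The step this estimate means, an at least 1.2-fold lower number from compound 2 to compound 4 (0.09 log units; that floor lies within the scatter), is expected to stay within the scatter.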

Compound 4, half-maximal cytotoxic concentration: > 50000 nM
Compound 4 gave a limit, no number (the forecaster's own chance of this, stated with the estimate: 50%); middle value at least 1.2-fold (0.09 log units) from the limit.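

Compound 2 and compound 4 both give a limit, not a number, so the step between them cannot be read: the limit of > 50000 nM in this assay, at which 2 of the 4 values shown sit.

Still open, going by these compounds, is whether 4-methoxyphenoxy in place of pyridin-4-yl changes the read-out in this assay at all, and in which direction.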